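Amide variation on the shared core: fluoro on the benzyl

The compounds below may be only part of what the source reports. "The series", "measured", "known", "first", "only" and "open" are said of these compounds alone.

Compound 1 `C=CC1=C(C(=O)NCCCCC)C(c2ccc(OC)cc2)OC1`: 36500 nM in a functional assay on A549 cells (Homo sapiens) for cytotoxicity, read by MTT assay, with a stated time of 24 h; a higher number here means a weaker inhibitor, a lower number a stronger inhibitor.
Compound 2 `C=CC1=C(C(=O)NC(C)(C)C)C(c2ccc(OC)cc2)OC1`: > 100000 nM, a limit of the assay and not a number.
Compound 3 `C=CC1=C(C(=O)NCc2ccccc2)C(c2ccc(OC)cc2)OC1`: > 100000 nM, likewise a limit of the assay.

Compound 3 stands at the limit of this assay, so only a bound is known for it, and the limit of > 100000 nM in this assay, at which 2 of the 3 values shown sit, frames how little the set resolves at the weak end. Of the measured steps that end at compound 3, an at least 2.7-fold higher number from compound 1 to compound 3 (0.43 log units; beyond the scatter), while a step that the two limits leave unreadable from compound 2 to compound 3. Compound 4 `C=CC1=C(C(=O)NCc2ccccc2F)C(c2ccc(OC)cc2)OC1` differs from compound 3 by fluoro in place of hydrogen on an aromatic carbon. Among the compounds with values here, none of the measured steps concerns a substituent on an aromatic ring of the amide-side chain; each of them exchanges the whole group on the amide-type nitrogen. Within the data shown here, no measured step therefore bears directly on the fluoro change, and no step beyond the scatter is expected from it. Compound 3 gives only a limit in this assay. Compound 4 is expected to give much the same, most probably again a limit, with an estimate of 100000 nM and a range from 40000 nM to 300000 nM. The expected step is a number no higher from compound 3 to compound 4 (the limit leaves the size open), no movement beyond the scatter.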

Compound 4, half-maximal inhibitory concentration: > 100000 nM
Compound 4 was reported as a limit; the forecaster's own chance of this, stated with the estimate: 70%; the middle value lies on the limit itself.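

With the 2-fluorobenzyl group on the amide nitrogen, the fluoro change leaves the series at the weak end of this assay. Compound 4 gives > 100000 nM, a limit of the assay and not a number. The steps from compound 3 and from compound 2 to compound 4 run between two limits and cannot be read, and the one readable step is an at least 2.7-fold higher number from compound 1 to compound 4 (0.43 log units; beyond the scatter), so the pentyl amide stays the only one of the four with a number and the weak end resolves little: the limit of > 100000 nM in this assay, at which 3 of the 4 values shown sit.

Going by these compounds, whether fluoro on this aromatic carbon moves the benzyl amide at all stays unknown, as any shift would lie hidden beyond the limit on both sides of the change. Also open, on these data alone, is how a chain longer than pentyl, or a pentyl chain ending in an amine or a carboxylic acid, would read in this assay, and so whether the number for the pentyl amide can be improved on the shared core.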